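A few compounds are considered here, and "the series" means these few. Any claim that something is new, unique, unknown or untested is made for them only; others in the source may bear on it.

For the measured compounds named here, in a physicochemical assay for lipophilicity (on this read-out lower numbers stand for lower lipophilicity and higher numbers for higher lipophilicity), three compounds sharing a core have numbers so far: compound 1 `Clc1cccc(C2=NC(c3ccccc3)CO2)c1` gives 4.44, compound 3 `Clc1ccc(C2=NC(c3ccccc3)CO2)c(Cl)c1` gives 4.4, and compound 2 `Clc1ccccc1C1=NC(c2ccccc2)CO1` gives 3.56, the lowest of the three. Compound 4 `Clc1ccc(Cl)c(C2=NC(c3ccccc3)CO2)c1` has not been measured and differs from compound 2 in one place: chloro in place of hydrogen on an aromatic carbon, with chloro in place of hydrogen on an aromatic carbon, meta to a large group and para to a chloro group. Going by the values given here, one measured step bears on this, the same replacement at a different place: a number 0.84 log units higher from compound 2 to compound 3 (beyond the scatter). Given that single step, a rise of similar size is expected in this assay. The estimated change is a number 0.79 log units higher from compound 2 to compound 4 (beyond the scatter). Compound 4 is expected at 4.35, with an estimated range from 4 to 4.7.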

Compound 4, partition coefficient: 4.4
Compound 4: middle estimate off by 0.05 log units, on the low side; the range from low to high includes it.
By their numbers in this assay, from the lowest: compound 2; then compounds 3, 4 and 1 (each within the scatter of the next).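

In this assay, chloro in place of hydrogen on an aromatic carbon, meta to a large group and para to a chloro group, gives a number 0.84 log units higher from compound 2 to compound 4 (beyond the scatter), a step that matches the one at the other place, a number 0.84 log units higher from compound 2 to compound 3 (beyond the scatter). The same kind of replacement starting elsewhere gives a number 0.04 log units lower from compound 1 to compound 4 (within the scatter), so the rise appears from compound 2 but not from compound 1. Nothing available explains this difference. As far as these compounds go, whether an amine or a carboxylic acid at this position would give a step of similar size remains open.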